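From compound 2 to compound 4: a bromo step

The source may report more compounds than this note shows. Statements on the series, on what has been measured and on what is new or still open speak of the compounds shown alone.

Measured so far in a functional assay on HCT-116 cells (Homo sapiens) for antiproliferative activity, read by MTT assay, with a stated time of 48 h (a higher number here means a weaker inhibitor, a lower number a stronger inhibitor), and set out here
- Compound 1 (`CCCC(CCO)n1cnc2c(Cl)ncnc21`) gives > 50000 nM as a limit
- Compound 2 (`CCCCCC(CCO)n1cnc2c(Cl)ncnc21`) gives > 50000 nM as a limit
- Compound 3 (`CCCCCC(CCO)n1cnc2c(Cl)nc(Cl)nc21`) gives 6170 nM as a number

Compound 2 has no number in this assay, only a limit (> 50000 nM) that it shares with one other compound. Its true position is therefore unknown, and any step starting from it has an open end.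

Compound 4 (`CCCCCC(CCO)n1c(Br)nc2c(Cl)ncnc21`) differs from compound 2 by a single change (bromo in place of hydrogen on an aromatic carbon) with bromo in place of hydrogen on an aromatic carbon, here on the five-membered aromatic ring.

The nearest measured change is an at least 8.1-fold lower number from compound 2 to compound 3 (0.90 log units; beyond the scatter) with chloro in place of hydrogen on an aromatic carbon, though on a different carbon. The other measured change is a step that the two limits leave unreadable from compound 1 to compound 2 and concerns the chain, so it gives no guide to size.

That leaves one uncertain precedent, from compound 3 at 6170 nM in the same assay. A lower number is expected, probably by less than that chloro step, and compound 4 may well stay at the limit. The expected change is an at least 2.5-fold lower number from compound 2 to compound 4 (0.39 log units; beyond the scatter) as an estimate. For compound 4 the estimated value is 20000 nM within an expected range from 6000 nM to 50000 nM in this assay.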

Compound 4, half-maximal inhibitory concentration: 18300 nM
The estimate for compound 4 lay 1.1-fold (0.04 log units) above the measured number, within the range that was stated.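

In this assay, within the data shown here, the aromatic carbon between two ring nitrogen atoms had carried only hydrogen in the earlier compounds, so nothing yet showed whether a change there would matter. Bromo in place of that hydrogen gives an at least 2.7-fold lower number from compound 2 to compound 4 (0.43 log units; beyond the scatter), so this carbon of the five-membered aromatic ring can take a group with a measurable number as the result. This is the second single change on an aromatic carbon to yield a number, after an at least 8.1-fold lower number from compound 2 to compound 3 (0.90 log units; beyond the scatter), though that chloro sits on a different carbon and the two changes cannot be sized against each other because compound 2 carries only a limit, not a number: the limit of > 50000 nM in this assay, at which 2 of the 4 values shown sit.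

Among the compounds shown, bromo is the only group other than hydrogen on this carbon, so it remains open whether the result depends on bromo itself or would also appear with a methyl, an amine or a longer chain in its place. Also open, on these data alone, is what would happen if bromo on this carbon were combined with the second chloro of compound 3 in a single molecule.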